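This account rests on a few compounds, and the source may have more. Where it says the series, first, only, none or still open, it means among the compounds named here.

Measured so far in a functional assay on MDA-MB-231 cells (Homo sapiens) for inhibition, read by MTT assay, with a stated time of 72 h; a higher number here means a weaker inhibitor, a lower number a stronger inhibitor:

Compound 1, `C=CC(=O)Nc1cccc(NC(=O)CSc2nc(Nc3ccccc3F)c3ccccc3n2)c1`, gives 18700 nM.
Compound 2, `C=CC(=O)Nc1cccc(NC(=O)CSc2nc(Nc3ccccc3Cl)c3ccccc3n2)c1`, gives 12700 nM.
Compound 3, `C=CC(=O)Nc1cccc(NC(=O)CSc2nc(Nc3ccccc3Br)c3ccccc3n2)c1`, gives 15200 nM.

Compound 3 stands between the other two numbers, and both neighbours lie within the scatter: the step of a 1.2-fold higher number from compound 2 to compound 3 (0.08 log units; within the scatter) and the step of a 1.2-fold lower number from compound 1 to compound 3 (0.09 log units; within the scatter) are each too small to count as a change. The three compounds share one core and differ only in the group on the aromatic carbon ortho to a large group, where fluoro, chloro and bromo have so far been tried.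

Compound 4, `C=CC(=O)Nc1cccc(NC(=O)CSc2nc(Nc3ccccc3C)c3ccccc3n2)c1`, is the next variation at that place: methyl in place of bromo on an aromatic carbon. Going by the values given here, none of the measured steps involves a methyl, so no step bears on it directly. What does bear on it is the whole set of swaps at this position, a 1.5-fold lower number from compound 1 to compound 2 (0.17 log units; within the scatter), a 1.2-fold higher number from compound 2 to compound 3 (0.08 log units; within the scatter) and a 1.2-fold lower number from compound 1 to compound 3 (0.09 log units; within the scatter), all within the scatter. On that basis compound 4 is expected to sit close to compound 3, with a step of a 1.0-fold lower number from compound 3 to compound 4 (0.01 log units; within the scatter), no larger than the scatter. The estimate for compound 4 is 15000 nM, within a range from 7000 nM to 32000 nM.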

Compound 4, half-maximal inhibitory concentration: 20400 nM
Estimate against measurement, compound 4: 1.4-fold (0.13 log units) below, within the range that was stated.
By their numbers in this assay, from the lowest: compounds 2, 3, 1 and 4 (each within the scatter of the next).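

Methyl is the first group at this place that is not a halogen, and in this assay it does not separate from any of them: the steps (a 1.3-fold higher number from compound 3 to compound 4 (0.13 log units; within the scatter)), (a 1.6-fold higher number from compound 2 to compound 4 (0.21 log units; within the scatter)) and (a 1.1-fold higher number from compound 1 to compound 4 (0.04 log units; within the scatter)) all stay within the scatter. Across fluoro, chloro, bromo and methyl on this aromatic carbon ortho to a large group, no swap therefore gives a readable change, and the four compounds cannot be put in order. Nothing given here accounts for this flat result.

As far as these compounds go, it remains open whether a different kind of group at this place, such as an amine, a carboxylic acid or a longer chain, would produce a step beyond the scatter. The compounds shown also leave open whether changes elsewhere on the shared core would do so.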